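Trimming a Methyl From a Sulfonamide Aromatase Inhibitor

The source may hold more compounds than are shown below. What is called first, only, known or untested is meant among the compounds shown, and "the series" means these compounds.

Measured so far:
Compound 1 `COc1ccc(S(=O)(=O)N2CCCC(Cn3ccnc3)C2)cc1OC` gives 42 nM in an assay on isolated protein for inhibition of Aromatase (Homo sapiens), read by fluorescence; a higher number here means a weaker inhibitor, a lower number a stronger inhibitor.
Compound 2 `COc1c(C)cc(S(=O)(=O)N2CCCC(Cn3ccnc3)C2)c(C)c1C` gives 45 nM in this assay.

Both compounds share a sulfonyl-linked piperidine carrying an imidazolylmethyl arm; they differ only in the substitution of the aromatic ring bearing the methoxy group. Compound 2 has three methyl groups on that ring where compound 1 has a second methoxy group instead. Despite this, the two numbers lie within the usual scatter of each other, so neither compound can be called the stronger inhibitor in this assay.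

Compound 3 `COc1ccc(S(=O)(=O)N2CCCC(Cn3ccnc3)C2)c(C)c1C` has not yet been measured. It differs from compound 2 by a single change: hydrogen in place of methyl on an aromatic carbon. Within the data shown here, no pair of measured compounds differs by exactly this change, so its effect has to be guessed. Given that the much larger difference between compound 1 and compound 2 left the numbers essentially unchanged, the loss of one methyl is expected to matter little, and the step from compound 2 to compound 3 is estimated as no change at the digits printed from compound 2 to compound 3 (within the scatter), not beyond the scatter in either direction. Compound 3 is therefore expected to give about 45 nM, with a plausible range from 20 nM to 100 nM.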

Compound 3, half-maximal inhibitory concentration: 59 nM
Compound 3: middle estimate off by 1.3-fold (0.12 log units), on the low side; the range from low to high includes it.
By their numbers in this assay, from the lowest: compounds 1, 2 and 3 (each within the scatter of the next).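

In this assay, among these compounds, hydrogen in place of methyl on this aromatic carbon gives a 1.3-fold higher number from compound 2 to compound 3 (0.12 log units; within the scatter), the first reading of a change made in this one place alone. At this carbon, ortho to a methoxy group and meta to a large group, the presence or absence of the methyl therefore makes no difference that can be told from the ordinary spread of repeated measurements. Nothing available accounts for this result or bears on how the methyl behaves at this position.

The compounds shown cover only hydrogen and methyl at this carbon, so it remains open whether a quite different group, such as an amine, a carboxylic acid or a longer chain, would also leave the number within the scatter. From the compounds shown here alone, it is also open whether the two remaining methyl groups on the ring could each be replaced by hydrogen with a similarly small step, and whether the same swap would give the same result on a different core.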